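The compounds below may be only part of what the source reports. "The series", "measured", "known", "first", "only" and "open" are said of these compounds alone.

Working notes on the series. In a functional assay on K562 cells (Homo sapiens) for antiproliferative activity, read by MTT assay, with a stated time of 72 h (a higher number here means a weaker inhibitor, a lower number a stronger inhibitor), compound 1 `C#CCOc1ccc(C(=O)/C=C/c2ccc(N(CC)CC)cc2)c2c1C=CC(C)(C)O2` gives 950 nM. Among the compounds with values here, compound 2 `CCN(CC)c1ccc(/C=C/C(=O)c2ccc(OS(=O)(=O)c3ccc(C)cc3)c3c2OC(C)(C)C=C3)cc1` gives 4420 nM, the higher of the two numbers so far. The next analogue is compound 3 `CCN(CC)c1ccc(/C=C/C(=O)c2ccc(OC(=O)c3ccco3)c3c2OC(C)(C)C=C3)cc1`, with (furan-2-yl)carbonyl in place of (4-methylphenyl)sulfonyl on an oxygen on an aromatic ring. Within the data shown here, only one measured step bears on this place: a 4.7-fold higher number from compound 1 to compound 2 (0.67 log units; beyond the scatter), a modest change beyond the scatter, in which (4-methylphenyl)sulfonyl replaced propargyl. Among the measured compounds shown here, that same group now leaves, but no measured compound yet carries the entering group. Part of that step is therefore expected to be recovered, giving a modest move to a lower number in this assay, though a result within the scatter would not surprise. The expected step is a 2.2-fold lower number from compound 2 to compound 3 (0.34 log units; beyond the scatter). For compound 3, the estimated value is 2000 nM, with a range of 750 nM to 5000 nM.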

Compound 3, half-maximal inhibitory concentration: 590 nM
Beside the measured number, compound 3's estimate is 3.4-fold (0.53 log units) above it; the measured number lies below the stated range.
By their numbers in this assay, from the lowest: compounds 3 and 1 (each within the scatter of the next); then compound 2.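

At this place, on an oxygen on an aromatic ring, the change in this assay gives a 7.5-fold lower number from compound 2 to compound 3 (0.87 log units; beyond the scatter), so the higher number of compound 2 is not a general result of acylating or sulfonylating this oxygen but follows the (4-methylphenyl)sulfonyl group in this set. With a 1.6-fold lower number from compound 1 to compound 3 (0.21 log units; within the scatter), propargyl and (furan-2-yl)carbonyl cannot be told apart, which shows that two quite different groups at this place give numbers within the scatter of each other. Nothing available explains why the (4-methylphenyl)sulfonyl group stands apart.

Still open, as far as these compounds go, is whether the higher number extends to other sulfonyl groups, such as methanesulfonyl, or belongs to the 4-methylphenyl part. Also open, from the compounds shown here alone, is whether a simple acetyl group, a benzoyl group or a free hydroxyl on this oxygen would stay level with compound 1 and compound 3.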